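The source may hold more compounds than are shown below. What is called first, only, known or untested is meant among the compounds shown, and "the series" means these compounds.

Compound 1 `O=C(/C=C/C1=Cc2ccccc2OC1)c1ccc(F)cc1`: 65.6%
Compound 2 `O=C(/C=C/C1=Cc2ccccc2OC1)c1ccc(C(F)(F)F)cc1`: 75.5%

In a functional assay on the whole organism for inhibition, with Mus musculus as the target, with a stated time of 1 h, at a dose of 30 mg/kg by the intraperitoneal route (on this read-out higher numbers stand for more inhibition at the one dose given (going by the name of the read-out) and lower numbers for less inhibition), compound 2 gives 75.5% and compound 1 gives 65.6%; the step of a number 9.9 percentage points higher from compound 1 to compound 2 (within the scatter) is within the scatter, so compound 2 stands level with compound 1 rather than ahead of it. Compound 3 `O=C(/C=C/C1=Cc2ccccc2OC1)c1ccc([N+](=O)[O-])cc1` differs from compound 2 by nitro in place of trifluoromethyl on an aromatic carbon. Within the data shown here, no measured step exchanges trifluoromethyl for nitro, and the only step known, fluoro to trifluoromethyl, stayed within the scatter. The step of a number 5.5 percentage points lower from compound 2 to compound 3 (within the scatter) is therefore expected to stay within the scatter as well. The estimate for compound 3 in this assay is 70%, within 52% to 85%.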

Compound 3, a percentage reported as inhibition, in the whole organism at one dose (the size of the read-out at that dose, not a potency): 50.8%
The estimate for compound 3 lay 19.2 percentage points above the measured number; the whole stated range lies above it.
By their numbers in this assay, from the lowest: compound 3; then compounds 1 and 2 (each within the scatter of the next).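

In this assay, among these compounds, this place on the aromatic ring proves sensitive to the group it carries: nitro gives the first steps beyond the scatter, (a number 24.7 percentage points lower from compound 2 to compound 3 (beyond the scatter)) and (a number 14.8 percentage points lower from compound 1 to compound 3 (beyond the scatter)). Fluoro and trifluoromethyl alone had shown no such separation, so compound 3 now stands apart from compounds 1 and 2. Nothing available explains this difference. On these data alone, whether an amine or a carboxylic acid at this place would fall with compound 3 or stand level with compounds 1 and 2 remains open.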